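The source may hold more compounds than are shown below. What is called first, only, known or untested is meant among the compounds shown, and "the series" means these compounds.

Measured so far in a functional assay on HeLa cells (Homo sapiens) for antiproliferative activity, read by CCK-8 assay, with a stated time of 72 h, tested at 2 uM; a lower number here means a weaker effect, a higher number a stronger effect of the compound at the concentration tested:

compound 1, `Nc1ccccc1NC(=O)c1ccc(CSC(=S)N2CCN(Cc3ccccn3)CC2)cc1`: 14.2%
compound 2, `CN1CCN(C(=S)SCc2ccc(C(=O)Nc3ccccc3N)cc2)CC1`: 52.6%
compound 3, `Nc1ccccc1NC(=O)c1ccc(CSC(=S)N2CCN(c3ccccc3F)CC2)cc1`: 17.5%

Compound 3 stands second highest of the three numbers; its nearest neighbour is compound 1, lower by an amount within the scatter, while compound 2 lies far above it, beyond the scatter. The two measured steps into compound 3 show the spread: a number 35.1 percentage points lower from compound 2 to compound 3 (beyond the scatter), a large drop, whereas a number 3.3 percentage points higher from compound 1 to compound 3 (within the scatter), within the scatter. Going by the values given here, the one large step in the set, a number 38.4 percentage points higher from compound 1 to compound 2 (beyond the scatter), likewise separates the small methyl group on the ring nitrogen from the larger substituents.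

Compound 4, `Nc1ccccc1NC(=O)c1ccc(CSC(=S)N2CCN(c3ccncc3)CC2)cc1`, is not yet measured. Relative to compound 3 the change is pyridin-4-yl in place of 2-fluorophenyl on an amine nitrogen in a ring. Among the compounds with values here, no measured step exchanges one aromatic group for another on this ring nitrogen, so none bears directly on the change. What the data do show is that the two compounds with a larger group on that nitrogen, compound 1 and compound 3, sit close together at the low end, and only compound 2 with methyl is high. Compound 4 keeps a six-membered aromatic group there, so it is expected to stay near compound 3, with an expected step of a number 1.5 percentage points higher from compound 3 to compound 4 (within the scatter), within the scatter. Compound 4 is therefore estimated at 19%, in the range 8% to 36%.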

Compound 4, a percentage reported as inhibition, at one concentration (the size of the read-out at that concentration, not a potency): 77%
Beside the measured number, compound 4's estimate is 58 percentage points below it; measured number outside the range, above it.
By their numbers in this assay, from the lowest: compounds 1 and 3 (each within the scatter of the next); then compound 2; then compound 4.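

In this assay, an aromatic group on the amine nitrogen in a ring is not tied to a low number: exchanging one six-membered aromatic ring for another gives a number 59.5 percentage points higher from compound 3 to compound 4 (beyond the scatter), so the nature of that ring matters strongly at this position, even though the change involves only the loss of fluorine and the entry of a ring nitrogen with one hydrogen-bond acceptor. The earlier pattern of low numbers for larger groups and a high number for methyl now has compound 4 against it, with a number 24.4 percentage points higher from compound 2 to compound 4 (beyond the scatter) and compound 4 the highest of the series, while a number 62.8 percentage points higher from compound 1 to compound 4 (beyond the scatter) shows that the presence of a pyridine ring is not sufficient, as the (pyridin-2-yl)methyl group of compound 1 sits at the low end. No available evidence accounts for the size of these steps.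

The compounds shown do not separate the loss of fluorine from the gain of the ring nitrogen, which unsubstituted phenyl on the same nitrogen would do. They also leave open whether the ring nitrogen's location or the direct attachment of the ring counts, a question that pyridin-3-yl and (pyridin-4-yl)methyl would address.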